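A few compounds are considered here, and "the series" means these few. Any claim that something is new, unique, unknown or untested is made for them only; others in the source may bear on it.

Measured in a functional assay on DU-145 cells (Homo sapiens) for antiproliferative activity, read by propidium iodide staining, with a stated time of 96 h; a higher number here means a weaker inhibitor, a lower number a stronger inhibitor:

Compound 1 `CC(O)(CSc1cccc(C(F)(F)F)c1)C(=O)Nc1ccc(S(F)(F)(F)(F)F)cc1` gives 26200 nM.
Compound 2 `CC(O)(CSc1ccccc1C(F)(F)F)C(=O)Nc1ccc(S(F)(F)(F)(F)F)cc1` gives 15800 nM.
Compound 3 `CC(O)(CSc1cccc(C(F)(F)F)c1)C(=O)Nc1cccc(S(F)(F)(F)(F)F)c1` gives 19100 nM.

Compound 4 `CC(O)(CSc1ccccc1C(F)(F)F)C(=O)Nc1cccc(S(F)(F)(F)(F)F)c1` has not yet been measured in this assay. It differs from compound 3 in one place: 2-(trifluoromethyl)phenyl in place of 3-(trifluoromethyl)phenyl on a sulfur. The same change, at the same place, links compound 1 to compound 2, where it gave a 1.7-fold lower number from compound 1 to compound 2 (0.22 log units; within the scatter). How the core of compound 1 differs from the core of compound 3 is not broken down here; the two values themselves lie within the scatter of each other. Going by the values given here, the step to compound 4 is expected to be of similar size, a 1.6-fold lower number from compound 3 to compound 4 (0.20 log units; within the scatter), because the only earlier instance of this change gave a 1.7-fold lower number from compound 1 to compound 2 (0.22 log units; within the scatter). Compound 4 is accordingly estimated at 12000 nM, likely falling between 5500 nM and 28000 nM.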

Compound 4, half-maximal inhibitory concentration: 15800 nM
Compound 4: middle estimate off by 1.3-fold (0.12 log units), on the low side; low and high end bracket the measured number.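

Putting 2-(trifluoromethyl)phenyl in place of 3-(trifluoromethyl)phenyl on the sulfur gives, in this assay, a 1.2-fold lower number from compound 3 to compound 4 (0.08 log units; within the scatter). Set beside the earlier case, the change behaves alike on both cores as far as these numbers can tell: the same change on two cores in this assay, a 1.7-fold lower number (0.22 log units; within the scatter) from compound 1 to compound 2 and a 1.2-fold lower number (0.08 log units; within the scatter) from compound 3 to compound 4, 1.4-fold (0.14 log units) apart, within the scatter of two such steps. Each step lies within the scatter, however, so the two pairs show no measurable difference in how the change carries over, but they do not show that it really alters the number on either core, and two cores are too few for a rule about the series.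

Still open, from the compounds shown here alone, is whether an amine or a carboxylic acid in place of the trifluoromethyl group, or a longer chain on the sulfur, would move the number beyond the scatter.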